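This account rests on a few compounds, and the source may have more. Where it says the series, first, only, none or still open, it means among the compounds named here.

Of the compounds shown here, two built on one shared core have been tested in an ADME assay on Vero cells (Chlorocebus sabaeus) for cytotoxicity, read by MTT assay, with a stated time of 72 h; on this read-out lower numbers stand for higher toxicity in this test and higher numbers for lower toxicity in this test. Compound 1 `CC1COC2(CCN(c3nc(=O)c4cc(C(F)(F)F)cc([N+](=O)[O-])c4s3)CC2)O1` gives > 125000 nM, which is a limit of the test rather than a number. Compound 2 `O=C(c1ccccc1Cl)N1CCN(c2nc(=O)c3cc(C(F)(F)F)cc([N+](=O)[O-])c3s2)CC1` gives > 125000 nM, also a limit. For compound 2 this is the limit of > 125000 nM in this assay, at which 2 of the 2 values shown sit. Compound 3 `O=C(C1CCC1)N1CCN(c2nc(=O)c3cc(C(F)(F)F)cc([N+](=O)[O-])c3s2)CC1` differs from compound 2 by cyclobutyl in place of 2-chlorophenyl on a carbonyl carbon. For the measured compounds named here, no measured step between two compounds shows how such a change shifts this read-out, so compound 3 is expected to remain at the same limit, with a number no higher from compound 2 to compound 3 (the limit leaves the size open) expected to be no change beyond the scatter. Compound 3 is therefore estimated at 125000 nM, within a range from 50000 nM to 125000 nM.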

Compound 3, half-maximal cytotoxic concentration: > 125000 nM
Compound 3 ended at the assay's limit; the forecaster's own chance of this, stated with the estimate: 85%; the middle value lies on the limit itself.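

No step can be read from compound 2 to compound 3, since each stands at a limit of this assay rather than at a number: the limit of > 125000 nM in this assay, at which 3 of the 3 values shown sit. The compounds shown leave open how far each one's true value lies beyond that limit, and so whether the change of group matters here.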